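A Methyl Added to the Hydroxymethyl Arm

The source may hold more compounds than are shown below. What is called first, only, known or untested is meant among the compounds shown, and "the series" means these compounds.

Compound 1, `COC(=O)[C@@H](NC(=O)c1cnc2ccccc2c1Cl)[C@@H](C)O`: in an ADME assay on CCRF-CEM cells (Homo sapiens) for cytotoxicity (on this read-out higher numbers stand for lower toxicity in this test and lower numbers for higher toxicity in this test), compound 1 gives > 100 uM, which is a limit of the assay.
Compound 2, `COC(=O)[C@H](CO)NC(=O)c1cnc2cc(C)ccc2c1Cl`: in this assay compound 2 gives 59.6 uM.

Going by the values given here, of the two measured compounds, compound 2 carries the only number in this assay; the other value is a limit, at which compound 1 sits (the limit of > 100 uM in this assay, at which 1 of the 2 values shown sits). Compound 3, `COC(=O)[C@@H](NC(=O)c1cnc2cc(C)ccc2c1Cl)[C@@H](C)O`, is the next step from compound 2: methyl in place of hydrogen on a saturated chain carbon bound to an oxygen on a saturated carbon and a saturated chain carbon. Among the compounds with values here, no step between measured compounds isolates this single change, so its size in this assay is not known from a direct pair.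

The expectation rests on the two values at hand. Compound 1, which also carries the 1-hydroxyethyl arm, gives > 100 uM in this assay, a limit. Compound 2, with the hydroxymethyl arm and the methyl on the core, gives 59.6 uM. A step from compound 2 to compound 3 of a 1.5-fold higher number from compound 2 to compound 3 (0.18 log units; within the scatter) toward lower toxicity is therefore expected, though it may not exceed the scatter. Compound 3 is estimated at 90 uM, in a range from 45 uM to 180 uM, with a fair chance that only a limit is reported.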

Compound 3, half-maximal toxic concentration: > 100 uM
Compound 3 was reported as a limit; the forecaster's own chance of this, stated with the estimate: 50%; middle value at least 1.1-fold (0.04 log units) from the limit.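

With the methyl on the core held constant, the change from hydroxymethyl to 1-hydroxyethyl gives, in this assay, an at least 1.6-fold higher number from compound 2 to compound 3 (0.22 log units; that floor lies within the scatter). Going by these compounds alone, this is the first direct reading of methyl in place of hydrogen on this saturated chain carbon, and because compound 3 is a limit, the figure is only a floor: the true step may be larger, but what can be read so far does not leave the scatter. Compound 1 and compound 3 differ only by methyl in place of hydrogen on an aromatic carbon, yet the step between them cannot be read, since both are limits, and so the methyl on the core has no readable size while the 1-hydroxyethyl arm is present: the limit of > 100 uM in this assay, at which 2 of the 3 values shown sit.

On these data alone, it remains open whether a longer chain or an amine on this saturated chain carbon would bring the read-out back to a measurable number, which would give this position a step of full size. As far as these compounds go, it also remains open how the hydroxymethyl arm reads on the core of compound 1, so the methyl on the core has no readable size in this assay on either arm.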